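Removing the Methoxy Group from Compound 3

The source may report more compounds than this note shows. Statements on the series, on what has been measured and on what is new or still open speak of the compounds shown alone.

Compound 1 `Cc1ccccc1-n1cc(CN2C(=O)C[C@@H]3CC[C@@]2(C)C3(C)C)nn1` gives 250 nM in a functional assay on PANC-1 cells (Homo sapiens) for inhibition, read by MTT assay, with a stated time of 24 h; a lower number here means a stronger inhibitor, a higher number a weaker inhibitor.
Compound 2 `CC1(C)[C@H]2CC[C@]1(C)N(Cc1cn(-c3ccccc3O)nn1)C(=O)C2` gives 230 nM.
Compound 3 `COc1ccc(-n2cc(CN3C(=O)C[C@@H]4CC[C@@]3(C)C4(C)C)nn2)cc1` gives 330 nM.

Compound 3 has the highest of the three numbers, but its steps from compound 1 a 1.3-fold higher number from compound 1 to compound 3 (0.12 log units; within the scatter) and from compound 2 a 1.4-fold higher number from compound 2 to compound 3 (0.16 log units; within the scatter) both lie within the scatter, so none of the three can be called stronger or weaker than another. Compound 4 `CC1(C)[C@H]2CC[C@]1(C)N(Cc1cn(-c3ccccc3)nn1)C(=O)C2` differs from compound 3 in one place: hydrogen in place of methoxy on an aromatic carbon. Going by the values given here, the steps that bear on this are the two just named, since each also swaps the group on the aromatic nitrogen, and both were small. No step beyond the scatter is therefore expected in this assay; the expected step is a 1.1-fold lower number from compound 3 to compound 4 (0.04 log units; within the scatter). Compound 4 is estimated at 300 nM, within 150 nM to 600 nM.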

Compound 4, half-maximal inhibitory concentration: 160 nM
Estimate against measurement, compound 4: 1.9-fold (0.27 log units) above, within the range that was stated.
By their numbers in this assay, from the lowest: compounds 4, 2, 1 and 3 (each within the scatter of the next, the first and the last beyond it).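

Going by these compounds alone, removing the methoxy gives the first step that lies beyond the scatter, though a modest one: in this assay there is a 2.1-fold lower number from compound 3 to compound 4 (0.31 log units; beyond the scatter) and the bare phenyl reads as the stronger inhibitor. Hydrogen does not separate from the hydroxy or methyl groups, with a 1.4-fold lower number from compound 2 to compound 4 (0.16 log units; within the scatter) and a 1.6-fold lower number from compound 1 to compound 4 (0.19 log units; within the scatter) both within the scatter. No measurement shown accounts for the methoxy step.

Only methoxy and hydrogen are compared on this aromatic carbon. From the compounds shown here alone, how an amine, a carboxylic acid or a longer chain such as ethoxy would read there remains open.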